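Adding a methyl to the amide-side aryl of compound 3

The compounds below may be only part of what the source reports. "The series", "measured", "known", "first", "only" and "open" are said of these compounds alone.

Compound 3 `COc1cc2c(Nc3nc4ccc(C(=O)Nc5c(C)cccc5C)cc4s3)ncnc2cc1OCCCN1CCCCC1C` sits at a limit: in a functional assay on DLD-1 cells (Homo sapiens) for cytotoxicity, read by WST assay, with a stated time of 72 h (on this read-out higher numbers stand for weaker inhibition and lower numbers for stronger inhibition), compound 3 gives > 100000 nM, which is a limit of the assay and not a number (the limit of > 100000 nM in this assay, at which 1 of the 3 values shown sits). Its nearest measured relative is compound 2 `COc1cc2c(Nc3nc4ccc(C(=O)Nc5c(C)cccc5Cl)cc4s3)ncnc2cc1OCCCN1CCCCC1C`, which in this assay gives 6700 nM; the measured step of an at least 14-fold higher number from compound 2 to compound 3 (1.17 log units; beyond the scatter) is the only one that bears directly on compound 3. Compound 1 `COc1cc2c(Nc3nc4ccc(C(=O)Nc5c(C)cc(C)cc5C)cc4s3)ncnc2cc1OCCCN1CCC(C)CC1` carries the same amide-side aryl that compound 4 would have, with a different methyl placement on the piperidine; in this assay compound 1 gives 7000 nM.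

The step to compound 4 `COc1cc2c(Nc3nc4ccc(C(=O)Nc5c(C)cc(C)cc5C)cc4s3)ncnc2cc1OCCCN1CCCCC1C` is methyl in place of hydrogen on an aromatic carbon. Among the measured compounds shown here, no measured pair shows this exact change, so the expectation rests on two observations. Compound 3 stands at a limit in this assay. Compound 1, with the trimethylphenyl amide, gives 7000 nM. The step is therefore expected to bring a lower number, of the order of an at least 3.3-fold lower number from compound 3 to compound 4 (0.52 log units; beyond the scatter), but with wide uncertainty since compound 3 only gives a limit and the chance that compound 4 also returns only a limit is real. The estimate for compound 4 in this assay is 30000 nM, within a range from 7000 nM to 150000 nM.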

Compound 4, half-maximal inhibitory concentration: 5700 nM
Estimate against measurement, compound 4: 5.3-fold (0.72 log units) above, outside the stated range (below it).
By their numbers in this assay, from the lowest: compounds 4, 2 and 1 (each within the scatter of the next). At a limit, above all of these: compound 3.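

On the 2,6-dimethylphenyl amide, methyl in place of hydrogen on the aromatic carbon para to the large group is a large change in this assay: an at least 17-fold lower number from compound 3 to compound 4 (1.24 log units; beyond the scatter). Going by these compounds, the true size of this step stays open, since the value for compound 3 is a limit of the assay and not a number: the limit of > 100000 nM in this assay, at which 1 of the 4 values shown sits. With the 2,4,6-trimethylphenyl amide in place, neither of the other two single changes separates the compounds, as 2-chloro-6-methylphenyl gives a 1.2-fold lower number from compound 2 to compound 4 (0.07 log units; within the scatter), and 4-methylpiperidin-1-yl gives a 1.2-fold lower number from compound 1 to compound 4 (0.09 log units; within the scatter).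

The compounds shown leave open whether this carbon needs a methyl specifically, or whether a methoxy group, a chlorine or a longer chain such as ethyl would place a compound with compound 4 rather than with compound 3. They also leave open whether the piperidine methyl matters on the 2,6-dimethylphenyl amide, since 4-methylpiperidin-1-yl is paired here only with the 2,4,6-trimethylphenyl amide, and the unsubstituted piperidine does not appear at all.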